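A few compounds are considered here, and "the series" means these few. Any claim that something is new, unique, unknown or untested is made for them only; others in the source may bear on it.

Measured so far, in a functional assay on the whole organism with Canis familiaris (Canis lupus familiaris) as the target, at a dose of 5 mg/kg by the intravenous route; a lower number here means a weaker effect, a higher number a stronger effect of the compound at the dose given:
- compound 1 `Cc1nc2c(OCc3ccccc3)cccn2c1CN` gives 49%
- compound 2 `CCNc1c(C)nc2c(OCc3ccccc3)cccn12` gives 70%
- compound 3 `Cc1nc2c(OCc3ccccc3)cccn2c1NC(C)C` gives 0%

Compound 3 stands lowest of the three numbers. Its nearest neighbour is compound 1, a number 49 percentage points lower from compound 1 to compound 3 (beyond the scatter); its furthest is compound 2, a number 70 percentage points lower from compound 2 to compound 3 (beyond the scatter). Both steps are beyond the scatter and both run downward toward compound 3, so the isopropylamino group marks the weak end of what has been measured in this assay.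

Compound 4 `Cc1nc2c(OCc3ccccc3)cccn2c1NCc1ccccc1` carries the change (benzyl in place of isopropyl on a nitrogen on an aromatic ring), that is, isopropylamino to benzylamino. Among the measured compounds shown here, no measured step touches a benzyl group, so the bearing of the three known steps is indirect. The step from compound 2 to compound 3, methyl in place of hydrogen on the saturated chain carbon bound to the nitrogen, was the largest downward move in the set; compound 4 removes that methyl again, though it adds a ring on the same carbon, a change for which no comparison exists. The step from compound 1 to compound 2 shows that a small unbranched group on this nitrogen can sit at the high end.

The expectation for compound 4 is therefore a recovery from compound 3, a number 35 percentage points higher from compound 3 to compound 4 (beyond the scatter), but with wide uncertainty because of a number 70 percentage points lower from compound 2 to compound 3 (beyond the scatter) having no parallel for a benzyl group. The estimate for compound 4 in this assay is 35%, within 0% to 75%.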

Compound 4, a percentage reported as inhibition, in the whole organism at one dose (the size of the read-out at that dose, not a potency): 0%
The estimate for compound 4 lay 35 percentage points above the measured number, within the range that was stated.
By their numbers in this assay, from the lowest: compounds 3 and 4 (each within the scatter of the next); then compound 1; then compound 2.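

In this assay, the benzylamino group gives the same reading as the isopropylamino group on a nitrogen on an aromatic ring, with no change at the digits printed from compound 3 to compound 4 (within the scatter), so exchanging isopropyl for benzyl at this position does not separate the two compounds. Compound 4 has no methyl branch on the saturated chain carbon bound to the nitrogen, yet phenyl in place of methyl there gives a number 70 percentage points lower from compound 2 to compound 4 (beyond the scatter), so among these compounds a branched chain is not needed for a reading far under that of the ethylamino compound, and the benzylamino compound also falls well short of the aminomethyl compound, with a number 49 percentage points lower from compound 1 to compound 4 (beyond the scatter). No measured evidence bearing on this result is available.

Open, on these data alone, is how a methyl group, an unbranched propyl chain or a longer unbranched chain on this nitrogen would read, which would show whether the high reading is confined to ethyl. Also open, as far as these compounds go, is whether a benzyl group carrying a carboxylic acid or an amine on its ring would differ from the plain benzyl group, and whether compound 3 and compound 4 would separate at doses other than the single one used here.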